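This account rests on a few compounds, and the source may have more. Where it says the series, first, only, none or still open, it means among the compounds named here.

Measured so far:
compound 1, `COc1ccc(N2C(=O)C(OC(C)=O)C2c2cc(OC)c(OC)c(OC)c2)cc1`, > 1000 nM
compound 2, `COc1ccc(N2C(=O)C(O)C2c2cc(OC)c(OC)c(OC)c2)cc1`, > 1000 nM
compound 3, `COc1ccc2cc(C3C(OC(C)=O)C(=O)N3c3cc(OC)c(OC)c(OC)c3)ccc2c1`, > 1000 nM

The three measured compounds were tested in a functional assay on IMR-32 cells (Homo sapiens) for cytotoxicity; on this read-out higher numbers stand for weaker inhibition and lower numbers for stronger inhibition. Compound 1, `COc1ccc(N2C(=O)C(OC(C)=O)C2c2cc(OC)c(OC)c(OC)c2)cc1`, gives only a limit of the assay, > 1000 nM. Compound 2, `COc1ccc(N2C(=O)C(O)C2c2cc(OC)c(OC)c(OC)c2)cc1`, likewise gives a limit, > 1000 nM. Compound 3, `COc1ccc2cc(C3C(OC(C)=O)C(=O)N3c3cc(OC)c(OC)c(OC)c3)ccc2c1`, also gives a limit, > 1000 nM. Because (the limit of > 1000 nM in this assay, at which 3 of the 3 values shown sit), none of the three steps between them can be read as a number.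

Compound 1 and compound 2 differ in one place, (hydrogen in place of acetyl on an oxygen on a saturated carbon), and the step that the two limits leave unreadable from compound 1 to compound 2. The same change is now made on a different core: compound 4, `COc1ccc2cc(C3C(O)C(=O)N3c3cc(OC)c(OC)c(OC)c3)ccc2c1`, differs from compound 3 by hydrogen in place of acetyl on an oxygen on a saturated carbon. How the core of compound 3 differs from the core of compound 1 is not broken down here. The place of the change is the same in both pairs, an oxygen on a saturated carbon whose other neighbour is a saturated ring carbon, so the two changes are the same change.

Since the change from compound 1 to compound 2 left both compounds at the limit, the step from compound 3 to compound 4 in this assay is expected to be a step that the limit leaves unreadable from compound 3 to compound 4, and compound 4 is expected to land again at or past the limit. The estimate for compound 4 is 3000 nM, between 800 nM and 20000 nM, with compound 4 most likely reported only as a limit.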

Compound 4, half-maximal inhibitory concentration: 89 nM
Compound 4: middle estimate off by 34-fold (1.53 log units), on the high side, and the stated range ends above it.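

In this assay, the change from acetoxy to hydroxy on the core of compound 3 gives an at least 11-fold lower number from compound 3 to compound 4 (1.05 log units; beyond the scatter), and compound 4 reads 89 nM, so on this core the change makes a clear difference. The same change on the core of compound 1 cannot be compared in size, so the data show neither that the change carries over to that core nor that it fails to, since the steps there cannot be read: the limit of > 1000 nM in this assay, at which 3 of the 4 values shown sit. This leaves one readable step on one core, which is a single result and not a rule for the series.

The compounds shown leave open how much of the drop on the core of compound 4 depends on the hydroxy itself, for instance whether an amine in its place, or a longer chain than acetyl on the same oxygen, would give a number close to that of compound 4. They also leave open whether any group at this place, such as an amine or a carboxylic acid, would bring the core of compound 1 to a value that can be read as a number rather than a limit.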